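Replacing Methoxy with a Chloro-Trifluoromethyl Phenyl Group

A few compounds are considered here, and "the series" means these few. Any claim that something is new, unique, unknown or untested is made for them only; others in the source may bear on it.

Compound 1 `CNC(=O)c1cc(Oc2ccc(NC(=O)c3cc4cccnc4n(-c4ccc(F)cc4)c3=O)cc2)ccn1` gives 160 nM in a functional assay on HT-29 cells (Homo sapiens) for antiproliferative activity, read by MTT assay, with a stated time of 72 h; a higher number here means a weaker inhibitor, a lower number a stronger inhibitor.
Compound 2 `CNC(=O)c1cc(Oc2ccc(NC(=O)c3cc4cccnc4n(-c4ccc(Cl)cc4)c3=O)cc2)ccn1` gives 390 nM in this assay.
Compound 3 `CNC(=O)c1cc(Oc2ccc(NC(=O)c3cc4cccnc4n(-c4ccc(OC)cc4)c3=O)cc2)ccn1` gives 920 nM in this assay.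

All three share one core and differ only in the group carried on the aromatic nitrogen. Compound 3 stands at the highest number of the three, which in this assay means the weakest inhibitor: compound 2 is nearest, a 2.4-fold higher number from compound 2 to compound 3 (0.37 log units; beyond the scatter), and compound 1 furthest, a 5.8-fold higher number from compound 1 to compound 3 (0.76 log units; beyond the scatter). Between the two halogens themselves, a 2.4-fold higher number from compound 1 to compound 2 (0.39 log units; beyond the scatter).

Compound 4 `CNC(=O)c1cc(Oc2ccc(NC(=O)c3cc4cccnc4n(-c4ccc(C(F)(F)F)cc4Cl)c3=O)cc2)ccn1` has not yet been measured. Its difference from compound 3 is this: 2-chloro-4-(trifluoromethyl)phenyl in place of 4-methoxyphenyl on an aromatic nitrogen. The measured steps that bear on it are the two in which methoxy replaced a halogen, a 5.8-fold higher number from compound 1 to compound 3 (0.76 log units; beyond the scatter) and a 2.4-fold higher number from compound 2 to compound 3 (0.37 log units; beyond the scatter), both of which raised the number. Within the data shown here, compound 4 moves the other way, from methoxy back to a ring bearing chlorine, though that ring also carries trifluoromethyl, a combination for which no measured step exists. A lower number than compound 3 is therefore expected, of a size comparable to the chloro step, with wide uncertainty: a 3.1-fold lower number from compound 3 to compound 4 (0.49 log units; beyond the scatter) is the expected step. Compound 4 is estimated at 300 nM in this assay, within a range from 80 nM to 1200 nM.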

Compound 4, half-maximal inhibitory concentration: 3190 nM
Beside the measured number, compound 4's estimate is 11-fold (1.03 log units) below it, and the stated range ends below it.
By their numbers in this assay, from the lowest: compound 1; then compound 2; then compound 3; then compound 4.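

Adding chlorine to the ring does not by itself lower the number at this position: the 2-chloro-4-(trifluoromethyl)phenyl group in place of 4-methoxyphenyl gives a 3.5-fold higher number from compound 3 to compound 4 (0.54 log units; beyond the scatter) in this assay and makes compound 4 the weakest inhibitor of the four. Set against the rings with a single halogen, the same group costs more, with an 8.2-fold higher number from compound 2 to compound 4 (0.91 log units; beyond the scatter) against the 4-chlorophenyl group and a 20-fold higher number from compound 1 to compound 4 (1.30 log units; beyond the scatter) against the 4-fluorophenyl group, the only large step in the series, so a halogen on this ring is no guarantee of a low number and the group on the aromatic nitrogen can shift the number substantially. Nothing available here accounts for this rise.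

Compound 4 brings in chlorine and trifluoromethyl together, so the compounds shown cannot say whether one of them alone, or only the two combined, produces the higher number; a ring carrying just one of them would separate the two. As far as these compounds go, how a ring bearing an amine or a carboxylic acid would behave on this nitrogen, or a simple methyl or a longer alkyl chain in place of the ring, also remains open.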